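The source may hold more compounds than are shown below. What is called first, only, known or untested is meant among the compounds shown, and "the series" means these compounds.

Three compounds sharing one core have been run in an ADME assay on HEK293 cells (Homo sapiens) for cytotoxicity, read by CellTiter-Glo and resazurin assay, with a stated time of 72 h; a higher number here means that more compound is needed for the effect, a lower number that less compound is needed. Compound 1 `CC(C)N(Cc1cccc(OCCCCCC(=O)O)c1)C(=O)c1ccc(-c2ccc3c(c2)OCCO3)cc1` gives > 21900 nM, which is a limit of the assay rather than a number. Compound 2 `CC(C)N(Cc1cccc(OCCCCCC(=O)O)c1)C(=O)c1ccc(-c2cccc(O)c2)cc1` gives > 26000 nM, also a limit. Compound 3 `CC(C)N(Cc1cccc(OCCCCCC(=O)O)c1)C(=O)c1ccc(-c2cccc(OC(F)(F)F)c2)cc1` gives > 26000 nM, again a limit. Compound 3 therefore stands at a limit, and so do the two others, as the lines the limit of > 21900 nM in this assay, at which 1 of the 3 values shown sits, and the limit of > 26000 nM in this assay, at which 2 of the 3 values shown sit, show, so none of the three can be placed above or below another. Compound 4 `COc1cc(F)cc(-c2ccc(C(=O)N(Cc3cccc(OCCCCCC(=O)O)c3)C(C)C)cc2)c1` differs from compound 3 only in 3-fluoro-5-methoxyphenyl in place of 3-(trifluoromethoxy)phenyl on an aromatic carbon. The measured steps that bear on this change are a step that the two limits leave unreadable from compound 1 to compound 3 and a step that the two limits leave unreadable from compound 2 to compound 3; both run between limits, so their size cannot be read and neither shows a step beyond the scatter. Compound 4 is therefore expected to show a number no higher from compound 3 to compound 4 (the limit leaves the size open), that is, no readable change. For compound 4 the estimate in this assay is 26000 nM, with a range from 15000 nM to 60000 nM, and most likely only a limit will be reported once more.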

Compound 4, half-maximal effective concentration: > 26000 nM
Compound 4 was reported as a limit; the forecaster's own chance of this, stated with the estimate: 85%; the middle value lies on the limit itself.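

In this assay compound 4 gives > 26000 nM, which is a limit and not a number. Its steps from compound 1, compound 2 and compound 3 all run between limits, so none can be read. The compounds shown leave open what concentration, if any, produces the effect for each of them.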